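Replacing 1,3-benzothiazol-2-yl with pyrimidin-2-yl

The source may report more compounds than this note shows. Statements on the series, on what has been measured and on what is new or still open speak of the compounds shown alone.

Compound 1 `c1ccc2c(c1)CN[C@H](CN(CCCN1CCNCC1)[C@H]1CCCc3cccnc31)C2` gives 88%
Compound 2 `c1cnc2c(c1)CCC[C@@H]2N(CCCN1CCNCC1)Cc1nc2ccccc2s1` gives 45%

Both numbers come from an ADME assay on microsomes from liver (Mus musculus) for metabolic stability, read by LC-MS, with a stated time of 10 min, tested at 0.5 uM (a lower number here means that less of the compound is left, a higher number that more of the compound is left), and are all that is known so far. Going by the values given here, of the two, compound 2 stands lowest with 45% in this assay and lies beyond the scatter from its only neighbour.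

Compound 3 `c1cnc(CN(CCCN2CCNCC2)[C@H]2CCCc3cccnc32)nc1` has not yet been measured. It differs from compound 2 in a single change, (pyrimidin-2-yl in place of 1,3-benzothiazol-2-yl on a saturated chain carbon bound to an amine nitrogen), which puts pyrimidin-2-yl in place of 1,3-benzothiazol-2-yl on a saturated chain carbon bound to an amine nitrogen.

Among the compounds with values here, one measured step bears on this place. It is a number 43 percentage points lower from compound 1 to compound 2 (beyond the scatter), large and beyond the scatter, and it came with 1,3-benzothiazol-2-yl in place of 1,2,3,4-tetrahydroisoquinolin-3-yl. Within the data shown here, no measured compound yet carries pyrimidin-2-yl, so the direction can only be inferred. Here 1,3-benzothiazol-2-yl leaves again, and compound 1, which lacks it, stands at 88% in this assay for comparison.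

An upward move is therefore expected, a number 25 percentage points higher from compound 2 to compound 3 (beyond the scatter), probably short of the full measured step. For compound 3 the estimated value is 70%, with an expected range from 50% to 90%.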

Compound 3, percent of the compound remaining: 78%
Beside the measured number, compound 3's estimate is 8 percentage points below it; measured number inside the range.
By their numbers in this assay, from the lowest: compound 2; then compounds 3 and 1 (each within the scatter of the next).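

At this saturated chain carbon bound to an amine nitrogen, the low number in this assay no longer looks like a general feature of aromatic groups: pyrimidin-2-yl in place of 1,3-benzothiazol-2-yl gives a number 33 percentage points higher from compound 2 to compound 3 (beyond the scatter) and so reverses much of the earlier loss. Pyrimidin-2-yl, one six-membered aromatic ring with 2 hetero atoms, and 1,2,3,4-tetrahydroisoquinolin-3-yl cannot be told apart here, with a number 10 percentage points lower from compound 1 to compound 3 (within the scatter) on that exchange, so among these three compounds only the one carrying 1,3-benzothiazol-2-yl stands apart. Nothing measured here accounts for the difference between these groups.

The compounds shown leave open whether the low number goes with the sulfur-bearing five-membered ring, with the fused pair of rings, or simply with the larger group, since the exchange alters all of these at once. A benzimidazol-2-yl, a benzoxazol-2-yl or a plain phenyl at this place would begin to separate those readings, and a pyridin-2-yl would test how much the second ring nitrogen of pyrimidin-2-yl matters.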